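The source may report more compounds than this note shows. Statements on the series, on what has been measured and on what is new or still open speak of the compounds shown alone.

Compounds measured so far:
compound 1, `CC(C)(N)C(=O)N[C@H](COCc1ccccc1)c1nnnn1CCCc1ccccc1`, 17 nM;
compound 2, `CC(C)(N)C(=O)N[C@H](COCc1ccccc1)c1nnn(Cc2ccccc2)n1`, 1120 nM;
compound 3, `CC(C)(N)C(=O)N[C@H](COCc1ccccc1)c1nnn(CCCCC#N)n1`, 1860 nM.

In a functional assay on H4 cells for agonist activity at growth hormone secretagogue receptor type 1 (Homo sapiens), read by FLIPR (a higher number here means that more compound is needed for the effect, a lower number that less compound is needed), compound 1 gives the lowest number of the three; compound 2 and compound 3 need far more material, and the step of a 1.7-fold higher number from compound 2 to compound 3 (0.22 log units; within the scatter) shows that swapping the phenyl there for a nitrile-bearing chain changed little. Going by the values given here, no measured step covers the change that leads to compound 4, `CC(C)(N)C(=O)N[C@H](COCc1ccccc1)c1nnnn1CCC(=O)NCc1ccccc1`: benzylcarbamoyl in place of benzyl on a saturated chain carbon, two bonds along the chain from an aromatic nitrogen. The chain grows by three atoms and gains an amide, while the aromatic ring is kept. On this evidence the step is expected to be moderate, a 2.9-fold higher number from compound 1 to compound 4 (0.47 log units; beyond the scatter), since the closest measured change stayed within the scatter. Compound 4 is therefore estimated at 50 nM, with a range of 15 nM to 200 nM.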

Compound 4, half-maximal effective concentration: 51 nM
Compound 4: the middle estimate sits 1.0-fold (0.01 log units) below what was measured; the range from low to high includes it.
By their numbers in this assay, from the lowest: compound 1; then compound 4; then compounds 2 and 3 (each within the scatter of the next).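

In this assay, replacing benzyl with benzylcarbamoyl on this saturated chain carbon, two bonds along the chain from an aromatic nitrogen, gives a 3.0-fold higher number from compound 1 to compound 4 (0.48 log units; beyond the scatter). Going by these compounds alone, this is the first measured step at this place, and it shows that the chain can carry an amide, with the aromatic ring kept, at a modest but real cost. The data shown offer no reason for the size of this step. On these data alone, the amide and the extra chain length enter together, so their separate contributions remain unknown. Also open, as far as these compounds go, is how a carboxylic acid or an amine would read in place of the benzylcarbamoyl group.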